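Pyrrolidine acids with aryl ethers: agonism at a fatty acid receptor

A few compounds are considered here, and "the series" means these few. Any claim that something is new, unique, unknown or untested is made for them only; others in the source may bear on it.

Measured compounds:
compound 1, `Cc1ccccc1COc1ccc(N2CCC[C@H]2CC(=O)O)cc1`, 190 nM
compound 2, `O=C(O)C[C@@H]1CCCN1c1ccc(Oc2ccccc2)cc1`, 560 nM
compound 3, `Cc1cccc(Oc2ccc(N3CCC[C@H]3CC(=O)O)cc2)c1`, 260 nM

In a functional assay on cells for agonist activity at Free fatty acid receptor 1 (Homo sapiens), read by FLIPR and calcium flux, with a stated time of 100 s (a lower number here means that less compound is needed, a higher number that more compound is needed for the effect), compound 3 gives the second highest of the three numbers. Its nearest neighbour is compound 1, with a 1.4-fold higher number from compound 1 to compound 3 (0.14 log units; within the scatter) between them; its furthest is compound 2, with a 2.2-fold lower number from compound 2 to compound 3 (0.33 log units; beyond the scatter).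

Compound 4, `Cc1ccc(Oc2ccc(N3CCC[C@H]3CC(=O)O)cc2)cc1`, is not yet measured. It differs from compound 3 by 4-methylphenyl in place of 3-methylphenyl on an oxygen on an aromatic ring.

Going by the values given here, two steps bear on this. The step of a 2.2-fold lower number from compound 2 to compound 3 (0.33 log units; beyond the scatter) shows that a methyl on that aromatic carbon gives a modest gain over the bare phenyl ether of compound 2. The step of a 2.9-fold higher number from compound 1 to compound 2 (0.47 log units; beyond the scatter) shows that the phenyl ether of compound 2 is modestly weaker than the 2-methylbenzyl ether of compound 1. Among the compounds with values here, no measured compound carries a 4-methylphenyl, so the effect of moving the methyl is untested; the expectation is a step no larger than these, most likely within the scatter of this assay.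

Compound 4 is therefore expected at 320 nM, with a range of 140 nM to 750 nM, an expected step of a 1.2-fold higher number from compound 3 to compound 4 (0.09 log units; within the scatter).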

Compound 4, half-maximal effective concentration: 490 nM
Compound 4: the middle estimate sits 1.5-fold (0.19 log units) below what was measured; the measured number falls inside the stated range.
By their numbers in this assay, from the lowest: compounds 1, 3, 4 and 2 (each within the scatter of the next, the first and the last beyond it).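

In this assay, moving the methyl from 3-methylphenyl to 4-methylphenyl on the oxygen gives a 1.9-fold higher number from compound 3 to compound 4 (0.28 log units; within the scatter), so the two groups cannot be told apart at this position. The earlier gain from adding a methyl to the bare phenyl ether does not hold for 4-methylphenyl, with a 1.1-fold lower number from compound 2 to compound 4 (0.06 log units; within the scatter), while the 2-methylbenzyl ether retains its advantage, with a 2.6-fold higher number from compound 1 to compound 4 (0.41 log units; beyond the scatter). No evidence here accounts for the size of these steps.

As far as these compounds go, whether a methoxy or trifluoromethyl group in place of the methyl would give a step beyond the scatter from the bare phenyl ether remains open. Also open, from the compounds shown here alone, is whether an unsubstituted benzyl ether would match the 2-methylbenzyl ether of compound 1.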